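The source may report more compounds than this note shows. Statements on the series, on what has been measured and on what is new or still open speak of the compounds shown alone.

Measured compounds in an assay on cell membranes from kidney for displacement of a labelled ligand from Translocator protein (Rattus norvegicus); on this read-out higher numbers stand for weaker inhibition and lower numbers for stronger inhibition:

compound 1, `CCN(Cc1ccccc1)C(=O)c1nc(-c2ccccc2Cl)c2ccccc2n1`: 0.235 nM
compound 2, `CCN(Cc1ccccc1)C(=O)c1nc(-c2ccc(F)cc2)c2ccccc2n1`: 1.68 nM
compound 3, `CCN(Cc1ccc(OC)cc1)C(=O)c1nc(-c2ccccc2)c2ccccc2n1`: 2.77 nM

Compound 3 gives the highest number of the three. Its gap to compound 2 lies within the scatter, so the two cannot be ordered; its gap to compound 1 lies beyond the scatter.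

Compound 4, `CCN(Cc1ccc(C(=O)O)cc1)C(=O)c1nc(-c2ccccc2)c2ccccc2n1`, differs from compound 3 in one place: carboxy in place of methoxy on an aromatic carbon. Going by the values given here, the only single-place step measured so far is a 7.1-fold higher number from compound 1 to compound 2 (0.85 log units; beyond the scatter), and that step changes the ring on the shared core, not the group on the benzyl ring. Compound 2 and compound 3 differ in two places at once, so their values give no clean reading either. Among the compounds with values here, no measured step therefore bears on the change from compound 3 to compound 4, and the expectation rests on the change itself, with a wide range.

Compound 4 is expected to give 30 nM, within 3 nM to 300 nM. The estimate means an expected step of an 11-fold higher number from compound 3 to compound 4 (1.03 log units; beyond the scatter) in this assay, towards a higher number.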

Compound 4, inhibition constant: 719 nM
Compound 4: middle estimate off by 24-fold (1.38 log units), on the low side, outside the stated range (above it).
By their numbers in this assay, from the lowest: compound 1; then compounds 2 and 3 (each within the scatter of the next); then compound 4.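

Going by these compounds alone, until now no single-place step had touched the benzyl ring, and in this assay the step of a 260-fold higher number from compound 3 to compound 4 (2.41 log units; beyond the scatter) shows that the group on this aromatic carbon, para to a large group, can shift the reading greatly. The move from 4-methoxybenzyl to 4-carboxybenzyl counts for far more here than the earlier change on the ring of the shared core, a 7.1-fold higher number from compound 1 to compound 2 (0.85 log units; beyond the scatter). No measurement at hand accounts for the size of this step.

The compounds shown leave open how a methyl ester, a primary amide or an amine at this place would read, and so whether the step is tied to the carboxy group itself. They also leave open whether the same change would weigh as heavily with the 2-chlorophenyl ring of compound 1 on the core.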